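Swapping a bromophenyl for a fluorophenyl: growth inhibition

A few compounds are considered here, and "the series" means these few. Any claim that something is new, unique, unknown or untested is made for them only; others in the source may bear on it.

Measured compounds:
Compound 1 `CCN(CC)Cc1c(O)c([C@H]2CCN(C)C[C@H]2O)c2oc(C)cc(=O)c2c1O`: 47%
Compound 2 `Cc1oc2c([C@H]3CCN(C)C[C@H]3O)c(O)cc(O)c2c(=O)c1C(O)c1ccccc1Br`: 52%

In a functional assay on HL-60 cells (Homo sapiens) for inhibition, read by MTT assay, with a stated time of 48 h, tested at 10 uM (on this read-out higher numbers stand for more inhibition of growth at the one concentration tested and lower numbers for less inhibition of growth), compound 2 gives 52%. Compound 1 gives 47%, and the two values lie within the usual scatter of each other, so neither can be called the more active. Compound 3 `Cc1oc2c([C@H]3CCN(C)C[C@H]3O)c(O)cc(O)c2c(=O)c1C(O)c1ccc(F)cc1` has not been measured. It differs from compound 2 in one place: 4-fluorophenyl in place of 2-bromophenyl on a saturated chain carbon bound to an aromatic carbon and an oxygen on a saturated carbon. Within the data shown here, no measured pair shows what such a change does here, so the step is expected to be none beyond the scatter. The estimate for compound 3 in this assay is 48%, between 30% and 66%. This estimate means an expected step of a number 4 percentage points lower from compound 2 to compound 3 (within the scatter).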

Compound 3, percent growth inhibition at one concentration: 30%
For compound 3 the middle estimate is 18 percentage points above the measured one; the measured number falls inside the stated range.
By their numbers in this assay, from the lowest: compound 3; then compounds 1 and 2 (each within the scatter of the next).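

In this assay the step is a number 22 percentage points lower from compound 2 to compound 3 (beyond the scatter) with 4-fluorophenyl in place of 2-bromophenyl, so the aryl group on this carbon does affect growth inhibition. Among these compounds, this is the first step between two compounds that differ in one place, and it is a single pair. Nothing at hand explains the drop.

The swap changes both the halogen and its place on the phenyl ring, and the compounds shown cannot separate the two. They also leave open how 4-bromophenyl, 2-fluorophenyl or plain phenyl would behave here.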